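The compounds below may be only part of what the source reports. "The series", "measured", "known", "first", "only" and "open" are said of these compounds alone.

Measured so far:
compound 1 `COc1cc(Cl)cc(-c2nn(-c3cccc(NC(=O)Nc4ccc(Cl)c(Cl)c4)c3)cc2-c2ccncc2)c1` — 9%
compound 2 `COc1cc(Cl)cc(-c2nn(-c3cccc(NC(=O)Nc4cccc(C(F)(F)F)c4)c3)cc2-c2ccncc2)c1` — -13%

In a functional assay on OVCAR-5 cells (Homo sapiens) for inhibition, read by sulforhodamine B assay, with a stated time of 48 h, tested at 100 uM (a higher number here means a weaker effect of the compound at the concentration tested, a lower number a stronger effect), compound 2 gives -13%, the lowest of the two numbers. Among the measured compounds shown here, the only measured step, a number 22 percentage points lower from compound 1 to compound 2 (beyond the scatter), concerns the aryl group on the amide-type nitrogen and nothing else. Compound 3 `COc1cc(Cl)cc(-c2nn(-c3cccc(NC(=O)c4cccc(C(F)(F)F)c4)c3)cc2-c2ccncc2)c1` differs from compound 2 by 3-(trifluoromethyl)phenyl in place of (3-(trifluoromethyl)phenyl)amino on a carbonyl carbon. For the measured compounds named here, no measured step touches that change, so no information on its direction is at hand; the expectation is a step of no more than the usual scatter, a number 5 percentage points higher from compound 2 to compound 3 (within the scatter). Compound 3 is estimated at -8%, between -30% and 20%.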

Compound 3, a percentage reported as activity, at one concentration (the size of the read-out at that concentration, not a potency): 59%
Beside the measured number, compound 3's estimate is 67 percentage points below it; measured number above the stated range.
By their numbers in this assay, from the lowest: compound 2; then compound 1; then compound 3.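

In this assay, placing 3-(trifluoromethyl)phenyl directly on the carbonyl carbon, without the amino nitrogen, gives a number 72 percentage points higher from compound 2 to compound 3 (beyond the scatter), so the effect at this position depends on more than the aryl group. The step of a number 50 percentage points higher from compound 1 to compound 3 (beyond the scatter) also changes the aryl substituents, yet it points the same way. Nothing at hand bears on the reason for this loss of effect.

Still open, going by these compounds, is whether a methylene or an oxygen in place of that nitrogen keeps the effect of compound 2. Also open, on these data alone, is whether 3,4-dichlorophenyl directly on the carbonyl carbon behaves as in compound 3.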